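The source may report more compounds than this note shows. Statements on the series, on what has been measured and on what is new or still open speak of the compounds shown alone.

Three compounds have been measured in an ADME assay on PANC-1 cells (Homo sapiens) for cytotoxicity, read by MTT assay, with a stated time of 48 h; a higher number here means a weaker inhibitor of growth, a lower number a stronger inhibitor of growth:
Compound 1, `O=C(/C=C\c1ccc(O)cc1)N1N=C(c2ccncc2)OC1c1c[nH]c2ccccc12`: > 30 ug/mL.
Compound 2, `O=C(/C=C\c1cccc([N+](=O)[O-])c1)N1N=C(c2ccncc2)OC1c1c[nH]c2ccccc12`: > 30 ug/mL.
Compound 3, `O=C(/C=C\c1ccc(Cl)cc1Cl)N1N=C(c2ccncc2)OC1c1c[nH]c2ccccc12`: > 30 ug/mL.

Each of these values is a limit of the assay and not a number. Compound 1 therefore stands at the limit of > 30 ug/mL in this assay, at which 3 of the 3 values shown sit, and nothing separates it from the other two. The steps among the measured compounds, a step that the two limits leave unreadable from compound 1 to compound 2, a step that the two limits leave unreadable from compound 1 to compound 3 and a step that the two limits leave unreadable from compound 2 to compound 3, are unreadable in size, each end being a limit. Compound 4, `O=C(/C=C\c1ccc(Br)cc1)N1N=C(c2ccncc2)OC1c1c[nH]c2ccccc12`, is not yet measured. It differs from compound 1 in one place: bromo in place of hydroxy on an aromatic carbon. Within the data shown here, no measured step exchanges hydroxy for bromo at this aromatic carbon, and the three steps that are known give no readable size, so no direction can be drawn from them. The writer expects compound 4 to remain with compound 1 at the limit, so that a step that the limit leaves unreadable from compound 1 to compound 4 is expected to be no step beyond the scatter. Compound 4 is estimated at 40 ug/mL, within a range from 15 ug/mL to 120 ug/mL.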

Compound 4, concentration for 50% growth inhibition: > 30 ug/mL
Compound 4: only a limit was reported; the forecaster's own chance of this, stated with the estimate: 75%; the middle value is on the limit's open side.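

In this assay compound 4 gives > 30 ug/mL, which is a limit of the assay and not a number. No step from compound 4 to compound 1, compound 2 or compound 3 can be read: the limit of > 30 ug/mL in this assay, at which 4 of the 4 values shown sit.

The compounds shown leave open how strongly any of them inhibits growth, and whether bromo in place of hydroxy makes any difference.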